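Lengthening the alkyl chain on a shared carbamate core

The source may report more compounds than this note shows. Statements on the series, on what has been measured and on what is new or still open speak of the compounds shown alone.

Of the compounds shown here, three built on one core have been measured in an assay on microsomes from intestine for inhibition of acyl-CoA:cholesterol acyltransferase (Oryctolagus cuniculus); on this read-out higher numbers stand for weaker inhibition and lower numbers for stronger inhibition. Compound 1 `CC(C)c1cccc(C(C)C)c1OC(=O)NC(=O)OCCCc1ccccc1` carries a phenyl on its chain, and in this assay compound 1 gives 660 nM. Compound 2 `CCCCCCCCCCOC(=O)NC(=O)Oc1c(C(C)C)cccc1C(C)C` has heptyl in place of that phenyl, and compound 2 gives 74 nM. Compound 3 `CCCCCCCCCCCOC(=O)NC(=O)Oc1c(C(C)C)cccc1C(C)C` has octyl in that place, and compound 3 gives 140 nM. Both the step of an 8.9-fold lower number from compound 1 to compound 2 (0.95 log units; beyond the scatter) and the step of a 4.7-fold lower number from compound 1 to compound 3 (0.67 log units; beyond the scatter) lie beyond the scatter, whereas the step of a 1.9-fold higher number from compound 2 to compound 3 (0.28 log units; within the scatter) stays within it. Compound 3 therefore stands second highest of the three numbers, with compound 2 as its nearest neighbour and compound 1 as its furthest.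

Compound 4 `CCCCCCCCCCCCCCOC(=O)NC(=O)Oc1c(C(C)C)cccc1C(C)C` differs from compound 3 by propyl in place of hydrogen on a saturated chain carbon, ten or more bonds along the chain from an oxygen next to a carbonyl group. Among the measured compounds shown here, the only measured step at this place on the chain is the one from compound 2 to compound 3, where methyl replaced hydrogen and the number moved only within the scatter. The present change is of the same kind but longer, and nothing measured here speaks for a large move in either direction. A small rise in the number, or none beyond the scatter, is expected. On that basis compound 4 is estimated at 200 nM, with a range from 70 nM to 600 nM, the expected step being a 1.4-fold higher number from compound 3 to compound 4 (0.15 log units; within the scatter).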

Compound 4, half-maximal inhibitory concentration: 10 nM
Estimate against measurement, compound 4: 20-fold (1.30 log units) above, outside the stated range (below it).
By their numbers in this assay, from the lowest: compound 4; then compounds 2 and 3 (each within the scatter of the next); then compound 1.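

The response at this place on the chain is not even from step to step: in this assay methyl in place of hydrogen had brought only a 1.9-fold higher number from compound 2 to compound 3 (0.28 log units; within the scatter) and gave no hint that propyl in place of hydrogen would bring a 14-fold lower number from compound 3 to compound 4 (1.15 log units; beyond the scatter) with a clear gain in inhibition. Butyl in place of hydrogen gives a 7.4-fold lower number from compound 2 to compound 4 (0.87 log units; beyond the scatter) and undecyl in place of phenyl gives a 66-fold lower number from compound 1 to compound 4 (1.82 log units; beyond the scatter) so that compound 4 is the strongest inhibitor of the four, and its steps to all the others lie beyond the scatter. Nothing available here explains why the number falls so sharply at this chain length.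

The compounds shown leave open whether a still longer chain would lower the number further or raise it again, since the chain lengths between those of compound 3 and compound 4 are also absent and the point at which the number falls cannot be located. They also leave open how an amine or a carboxylic acid at the far end of the chain would compare with the plain alkyl chain of compound 4 in this assay.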